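One Oxygen Added to the Side Chain of Compound 2

This account rests on a few compounds, and the source may have more. Where it says the series, first, only, none or still open, it means among the compounds named here.

Of the compounds shown here, two have so far been tested in a functional assay on the whole organism with Rattus norvegicus as the target, with a stated time of 4 h, at a dose of 40 mg/kg by the intraperitoneal route; on this read-out lower numbers stand for less inhibition and higher numbers for more inhibition at the one dose given (going by the name of the read-out). Compound 1 `CC(=O)c1c(C)nc2c(OCc3ccccc3)cccn12` gives 57% in this assay, and compound 2 `CSCc1c(C)nc2c(OCc3ccccc3)cccn12` gives 29%. Compound 2 thus stands lowest of the two numbers shown; its nearest neighbour is compound 1, and the single measured step, a number 28 percentage points lower from compound 1 to compound 2 (beyond the scatter), is the only comparison available.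

Compound 3 `Cc1nc2c(OCc3ccccc3)cccn2c1C[S+](C)[O-]` has not yet been measured. It differs from compound 2 by a group of 3 heavy atoms (1 carbon, 1 oxygen, 1 sulfur; no ring) in place of a group of 2 heavy atoms (1 carbon, 1 sulfur; no ring), on a saturated chain carbon bound to an aromatic carbon. Within the data shown here, no measured step concerns a change of this kind: the one known step, from compound 1 to compound 2, exchanged an acetyl on an aromatic carbon for the methylsulfanylmethyl chain and was of modest size, so it bears only loosely on what follows when the methylsulfanyl itself is altered. In the absence of a directly comparable step, no change beyond the scatter is expected in this assay, in either direction. For compound 3 the inhibition is therefore estimated at 35%, within a range from 10% to 60%. The expected step is a number 6 percentage points higher from compound 2 to compound 3 (within the scatter).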

Compound 3, a percentage reported as inhibition, in the whole organism at one dose (the size of the read-out at that dose, not a potency): 0%
Compound 3: the middle estimate sits 35 percentage points above what was measured; the whole stated range lies above it.
By their numbers in this assay, from the lowest: compound 3; then compound 2; then compound 1.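

The earlier pair showed only that the methylsulfanylmethyl chain could stand in place of acetyl on an aromatic carbon at a cost, and it left the chain's sulfur end untested. In this assay the change made at that end, on a saturated chain carbon bound to an aromatic carbon, brings a number 29 percentage points lower from compound 2 to compound 3 (beyond the scatter), so the group that enters in place of methylsulfanyl leaves compound 3 with 0% and shows that the read-out is sensitive to a small alteration of this chain. Measured against the acetyl compound, the whole exchange amounts to a number 57 percentage points lower from compound 1 to compound 3 (beyond the scatter), and nothing shown here bears on what lies behind this loss.

The compounds shown leave open whether a methylsulfonyl group, a methoxy group or a dimethylamino group at the same place would stay at this low end, return to the level of compound 2 or rise toward that of compound 1. They also leave open whether the loss seen at the single dose and stated time would hold at other doses or times.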